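This account rests on a few compounds, and the source may have more. Where it says the series, first, only, none or still open, it means among the compounds named here.

Measured compounds: compound 1 `CC(C)(C)c1ccc(S(=O)(=O)Nc2ccc(Cl)cc2-c2ncccc2N)cc1` with 95 nM; compound 2 `CC(C)(C)c1ccc(S(=O)(=O)Nc2ccc(Cl)cc2-c2nccc(C(N)=O)c2O)cc1` with 52 nM; compound 3 `CC(C)(C)c1ccc(S(=O)(=O)Nc2ccc(Cl)cc2-c2nccc(CO)c2O)cc1` with 8.7 nM, all in a functional assay on isolated protein for antagonist activity at C-C chemokine receptor type 9 (Homo sapiens), read by calcium flux, with a stated time of 10 min; on this read-out higher numbers stand for weaker inhibition and lower numbers for stronger inhibition.

Compound 3 stands lowest of the three numbers: an 11-fold lower number from compound 1 to compound 3 (1.04 log units; beyond the scatter) and a 6.0-fold lower number from compound 2 to compound 3 (0.78 log units; beyond the scatter), both beyond the scatter, so it is the strongest inhibitor measured here. Compound 4 `CC(C)(C)c1ccc(S(=O)(=O)Nc2ccc(Cl)cc2-c2nc(N)ncc2O)cc1` differs from compound 3 by a group of 8 heavy atoms (4 carbon, 3 nitrogen, 1 oxygen; one six-membered aromatic ring with 2 hetero atoms) in place of a group of 9 heavy atoms (6 carbon, 1 nitrogen, 2 oxygen; one six-membered aromatic ring with 1 hetero atom), on an aromatic carbon. Among the measured compounds shown here, no measured step matches this change exactly; the steps that bear on it are those that end at compound 3, since both remove the ring that compound 4 also lacks, and both were large. Compound 1, which carries an amino group on its ring, is the weakest. Compound 4 is therefore expected to fall between compound 1 and compound 3, giving 40 nM (range 12 nM to 130 nM), which would mean a 4.6-fold higher number from compound 3 to compound 4 (0.66 log units; beyond the scatter).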

Compound 4, half-maximal inhibitory concentration: 4 nM
Beside the measured number, compound 4's estimate is 10-fold (1.00 log units) above it; the whole stated range lies above it.
By their numbers in this assay, from the lowest: compound 4; then compound 3; then compounds 2 and 1 (each within the scatter of the next).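

In this assay, a ring with two hetero atoms at this place on the shared core goes beyond the best of the earlier rings, with a 2.2-fold lower number from compound 3 to compound 4 (0.34 log units; beyond the scatter), so neither hydroxymethyl nor carbamoyl is required for a low number here. The gaps to the other compounds are wider, with a 13-fold lower number from compound 2 to compound 4 (1.11 log units; beyond the scatter) and a 24-fold lower number from compound 1 to compound 4 (1.38 log units; beyond the scatter), which makes compound 4 the strongest inhibitor of the four. No measurement shown here accounts for this result.

The whole ring changes in this step, so the contributions of its second ring nitrogen, its amine and its hydroxyl remain unseparated. From the compounds shown here alone, whether a methylamine or a carboxylic acid in place of that amine would keep the number this low also remains open.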